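Benzofuran Ketone Piperazines: Aryl Swap on the Distal Nitrogen

The source may report more compounds than this note shows. Statements on the series, on what has been measured and on what is new or still open speak of the compounds shown alone.

Measured so far:
compound 1, `C#CCN1CCN(CC(=O)N2CCN(c3ccc(C(=O)c4cc5ccc(N(CC)CC)cc5o4)cc3)CC2)CC1`, 20100 nM
compound 2, `CCN(CC)c1ccc2cc(C(=O)c3ccc(N4CCN(C(=O)CN5CCN(Cc6ccc(/C=C/C(=O)OC)cc6)CC5)CC4)cc3)oc2c1`, 740 nM

In a functional assay on SGC-7901 cells (Homo sapiens) for cytotoxicity, read by MTT assay, with a stated time of 48 h (a higher number here means a weaker inhibitor, a lower number a stronger inhibitor), compound 2 gives 740 nM, the lower of the two numbers; compound 1 gives 20100 nM. For the measured compounds named here, the single measured step, a 27-fold lower number from compound 1 to compound 2 (1.43 log units; beyond the scatter), shows that an aryl group at this position matters greatly. Compound 3, `CCN(CC)c1ccc2cc(C(=O)c3ccc(N4CCN(C(=O)CN5CCN(Cc6ccc(F)c(F)c6)CC5)CC4)cc3)oc2c1`, carries 3,4-difluorophenyl in place of 4-(2-(methoxycarbonyl)ethenyl)phenyl on a saturated chain carbon bound to an amine nitrogen in a ring. Going by the values given here, no measured step compares two different aryl groups here, so only the retention of an aromatic ring can be relied upon. Compound 3 is therefore expected to stay near compound 2, with a step of a 1.5-fold higher number from compound 2 to compound 3 (0.17 log units; within the scatter), estimated at 1100 nM within 300 nM to 4500 nM.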

Compound 3, half-maximal inhibitory concentration: 1780 nM
Beside the measured number, compound 3's estimate is 1.6-fold (0.21 log units) below it; low and high end bracket the measured number.
By their numbers in this assay, from the lowest: compound 2; then compound 3; then compound 1.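

In this assay, for the compounds shown here, the step of a 2.4-fold higher number from compound 2 to compound 3 (0.38 log units; beyond the scatter) is the first measured comparison of two aryl groups at this position, and it shows that the choice of aryl group counts, not only the presence of an aromatic ring. The 3,4-difluorophenyl group still keeps most of the advantage over ethynyl, with an 11-fold lower number from compound 1 to compound 3 (1.05 log units; beyond the scatter) as its step. No measured evidence is available to explain these differences.

The compounds shown leave open whether the gap between the two aryl groups follows the fluorines or the methoxycarbonyl ethenyl chain. An unsubstituted phenyl, or a carboxylic acid in place of the methyl ester, would bear on that question.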